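Urea series: trifluoromethyl in place of ethoxycarbonyl

The compounds below may be only part of what the source reports. "The series", "measured", "known", "first", "only" and "open" are said of these compounds alone.

Measured compounds:
compound 1 `CCOC(=O)c1ccc(NC(=O)N2CC2C#N)cc1` gives 2900 nM in a functional assay on A549 cells (Homo sapiens) for inhibition; on this read-out lower numbers stand for stronger inhibition and higher numbers for weaker inhibition
compound 2 `CCCCNC(=O)N1CC1C#N` gives 18000 nM in this assay
compound 3 `CNC(=O)N1CC1C#N` gives 22000 nM in this assay

Compound 1 stands at the lowest number of the three in this assay, and its distance from compound 2 and from compound 3 is in each case beyond the scatter. Among the compounds with values here, the only single-change step measured so far, a 1.2-fold higher number from compound 2 to compound 3 (0.09 log units; within the scatter), concerns the chain on the urea nitrogen and not the aromatic end of the molecule.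

Compound 4 `N#CC1CN1C(=O)Nc1ccc(C(F)(F)F)cc1` differs from compound 1 by trifluoromethyl in place of ethoxycarbonyl on an aromatic carbon. Within the data shown here, no measured step touches a substituent on the aromatic carbon, so the data give no direction for this change; the expectation rests only on compound 1 as the nearest measured neighbour, at 2900 nM in this assay. For compound 4 the expected step is a 1.0-fold higher number from compound 1 to compound 4 (0.01 log units; within the scatter), not clearly beyond the scatter. Compound 4 is estimated at 3000 nM, with a range from 900 nM to 10000 nM.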

Compound 4, half-maximal inhibitory concentration: 4300 nM
Estimate against measurement, compound 4: 1.4-fold (0.16 log units) below; low and high end bracket the measured number.
By their numbers in this assay, from the lowest: compounds 1 and 4 (each within the scatter of the next); then compounds 2 and 3 (each within the scatter of the next).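

The aromatic carbon now has its first measured step: in this assay, trifluoromethyl in place of ethoxycarbonyl gives a 1.5-fold higher number from compound 1 to compound 4 (0.17 log units; within the scatter) and so stays within the scatter. At this place, the read-out does not separate ethoxycarbonyl, with its hydrogen-bond acceptors and double bond outside the aromatic ring, from trifluoromethyl, which has neither. No measurement at hand explains why the two groups read alike.

Within the data shown here, what an amine, a carboxylic acid or a plain hydrogen on this aromatic carbon would give stays open, so this place is described by only two groups. Also open, on these data alone, is whether any group here can shift the number beyond the scatter in either direction.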